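A few compounds are considered here, and "the series" means these few. Any claim that something is new, unique, unknown or untested is made for them only; others in the source may bear on it.

Measured compounds:
Compound 1, `c1ccc(COc2ccc(C3CC(c4ccc5c(c4)OCCO5)=NN3c3ccccc3)cc2)cc1`: 1130 nM
Compound 2, `FC(F)(F)c1ccc(C2CC(c3ccc4c(c3)OCCO4)=NN2c2ccccc2)cc1`: > 100000 nM
Compound 3, `COc1ccc(C2CC(c3ccc4c(c3)OCCO4)=NN2c2ccccc2)cc1OC`: 2160 nM

In a functional assay on WM 266-4 cells (Homo sapiens) for antiproliferative activity, read by MTT assay, with a stated time of 24 h (on this read-out higher numbers stand for weaker inhibition of growth and lower numbers for stronger inhibition of growth), compound 3 gives 2160 nM, the higher of the two numbers that were recorded; its nearest neighbour is compound 1, and the gap between them lies within the usual scatter, so the two cannot be told apart. For compound 2 the assay reports only a limit, > 100000 nM, and that value is one of the measurements sitting at the limit of > 100000 nM in this assay, at which 1 of the 3 values shown sits.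

Compound 4, `Fc1ccc(C2CC(c3ccc4c(c3)OCCO4)=NN2c2ccccc2)cc1`, has yet to be measured. It differs from compound 3 in one place: 4-fluorophenyl in place of 3,4-dimethoxyphenyl on a saturated ring carbon.

Among the compounds with values here, two measured steps bear on this change, both involving the 4-(trifluoromethyl)phenyl group on the same saturated ring carbon. The step of an at least 88-fold higher number from compound 1 to compound 2 (1.94 log units; beyond the scatter) was large, and the step of an at least 46-fold lower number from compound 2 to compound 3 (1.66 log units; beyond the scatter) was equally large in the opposite sense. Whether a 4-fluorophenyl group behaves more like the 4-(trifluoromethyl)phenyl of compound 2 or like the 3,4-dimethoxyphenyl of compound 3 is not settled by these compounds, so the expected step is a rise in number with wide uncertainty, a 6.9-fold higher number from compound 3 to compound 4 (0.84 log units; beyond the scatter). Compound 4 is therefore estimated at 15000 nM, with a range from 2500 nM to 100000 nM.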

Compound 4, concentration for 50% growth inhibition: 6050 nM
Compound 4: the middle estimate sits 2.5-fold (0.39 log units) above what was measured; the measured number falls inside the stated range.
By their numbers in this assay, from the lowest: compounds 1 and 3 (each within the scatter of the next); then compound 4. At a limit, above all of these: compound 2.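

At this saturated ring carbon, a phenyl group need not carry an oxygen substituent to keep a measurable number in this assay: 4-fluorophenyl in place of 3,4-dimethoxyphenyl gives only a modest loss, a 2.8-fold higher number from compound 3 to compound 4 (0.45 log units; beyond the scatter), and fluoro in place of benzyloxy gives a similarly modest one, a 5.4-fold higher number from compound 1 to compound 4 (0.73 log units; beyond the scatter). The collapse seen with trifluoromethyl therefore does not follow simply from the absence of an oxygen-bearing group, since the change from trifluoromethyl to fluoro on the same aromatic carbon is large, an at least 16-fold lower number from compound 2 to compound 4 (1.21 log units; beyond the scatter). The value of compound 2 is a limit and not a number, so the true size of that step stays unknown: the limit of > 100000 nM in this assay, at which 1 of the 4 values shown sits.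

The compounds shown do not explain why fluoro and trifluoromethyl part so widely, and a single fluoro cannot show whether a chloro, a methyl or a hydroxy on the same aromatic carbon would fall nearer to compound 4 or to compound 2. They also leave open whether an amine or a carboxylic acid there would match the benzyloxy of compound 1 or the two methoxy groups of compound 3.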